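The source may report more compounds than this note shows. Statements on the series, on what has been measured and on what is new or still open speak of the compounds shown alone.

Measured so far in an ADME assay on MCF-10A cells (Homo sapiens) for cytotoxicity, read by sulforhodamine B assay, with a stated time of 48 h; on this read-out lower numbers stand for stronger inhibition of growth and higher numbers for weaker inhibition of growth:
- compound 1, `Cc1ccc2nc(/N=C3\C(=O)N(CN4CCCCC4)c4ccccc43)sc2c1`: 38900 nM
- compound 2, `CN(C)CN1C(=O)C(=O)c2c(Br)cccc21`: 67800 nM
- compound 3, `Cc1ccc2nc(/N=C3\C(=O)N(CN4CCCCC4)c4cccc(Br)c43)sc2c1`: 18400 nM

Compound 3 and compound 1 share a core and differ in one place, (hydrogen in place of bromo on an aromatic carbon); in this assay the step was a 2.1-fold higher number from compound 3 to compound 1 (0.33 log units; beyond the scatter). Compound 2 sits on a different core; the difference between the core of compound 2 and that of compound 3 is not broken down here. Compound 2 has the highest number of the three, and its number and that of compound 1 lie within the scatter of each other, so no order between the two is claimed.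

Compound 4, `CN(C)CN1C(=O)C(=O)c2ccccc21`, is not yet measured. It differs from compound 2 by hydrogen in place of bromo on an aromatic carbon, and the place lines read the same word for word as for the change from compound 3 to compound 1, so this is the same change, made a second time on a different core. Placed beside the earlier step, the step from compound 2 to compound 4 is expected to be a 1.8-fold higher number from compound 2 to compound 4 (0.25 log units; within the scatter), resting on the step of a 2.1-fold higher number from compound 3 to compound 1 (0.33 log units; beyond the scatter) and on the value of compound 2, 67800 nM. From the compounds shown here alone, whether the change carries over to the second core is untested. For compound 4 in this assay the estimate is 120000 nM, with a range from 60000 nM to 250000 nM.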

Compound 4, concentration for 50% growth inhibition: 150000 nM
For compound 4 the middle estimate is 1.3-fold (0.10 log units) below the measured one, within the range that was stated.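

On the core of compound 2, hydrogen in place of bromo on an aromatic carbon gives a 2.2-fold higher number from compound 2 to compound 4 (0.34 log units; beyond the scatter) in this assay. Set beside the earlier step, the change carries over between these two cores with no difference in size beyond the scatter: the same change on two cores in this assay, a 2.1-fold higher number (0.33 log units; beyond the scatter) from compound 3 to compound 1 and a 2.2-fold higher number (0.34 log units; beyond the scatter) from compound 2 to compound 4, 1.0-fold (0.02 log units) apart, within the scatter of two such steps

Going by these compounds alone, this rests on only two matched pairs, each with a modest step, at one place and in one assay, so it does not show that the change would carry over to any further core or that other replacements would transfer in the same way.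

The compounds shown have only bromo or hydrogen at this place, which leaves open what a chloro group, a methoxy group or an amine would do there. Also open, from the compounds shown here alone, is whether the step holds when the amine side chains of the two cores are exchanged or replaced by a longer chain.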